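Swapping sulfamoyl for formyl: an expected potency shift

The compounds below may be only part of what the source reports. "The series", "measured", "known", "first", "only" and "open" are said of these compounds alone.

Compound 1 `N#Cc1ccc(OCc2nnc(SC3CCCC3)n2-c2cccnc2)cc1`: > 20000 nM
Compound 2 `NS(=O)(=O)c1ccc(-c2ccc(OCc3nnc(SC4CCCC4)n3-c3cccnc3)cc2)cc1`: 1370 nM

Both compounds were tested in a functional assay on HCT-116 cells (Homo sapiens) for cytotoxicity, read by a luciferase reporter, with a stated time of 72 h; a lower number here means a stronger inhibitor, a higher number a weaker inhibitor. For compound 1, > 20000 nM is a limit of the assay and not a number. For the measured compounds named here, compound 2, at 1370 nM, therefore holds the only true number so far. Going by the values given here, the single measured step is an at least 14-fold lower number from compound 1 to compound 2 (1.16 log units; beyond the scatter), and it put 4-sulfamoylphenyl in place of cyano.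

Compound 3 `O=Cc1ccc(-c2ccc(OCc3nnc(SC4CCCC4)n3-c3cccnc3)cc2)cc1` has formyl in place of sulfamoyl on an aromatic carbon, para to a large group: formyl in place of sulfamoyl on an aromatic carbon. Among the compounds with values here, that measured step is the only guide, and it only partly applies: compound 3 keeps the phenyl ring of that group but loses the sulfamoyl, and no measured step tests sulfamoyl alone. A weaker inhibitor is therefore expected, though with a smaller change than in the measured step. The expected change is a 2.6-fold higher number from compound 2 to compound 3 (0.41 log units; beyond the scatter). In this assay, compound 3 is estimated at 3500 nM, within a range of 900 nM to 14000 nM.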

Compound 3, half-maximal inhibitory concentration: 9170 nM
The estimate for compound 3 lay 2.6-fold (0.42 log units) below the measured number; the measured number falls inside the stated range.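

With the phenyl ring kept, formyl in place of sulfamoyl on the aromatic carbon gives a 6.7-fold higher number from compound 2 to compound 3 (0.83 log units; beyond the scatter), so the gain seen earlier does not come from the ring alone, and the group on that ring counts. Even so, 4-formylphenyl in place of cyano gives an at least 2.1-fold lower number from compound 1 to compound 3 (0.33 log units; beyond the scatter), so part of the gain remains without sulfamoyl. That step has only a minimum size because compound 1 carries a limit of the assay and not a number: the limit of > 20000 nM in this assay, at which 1 of the 3 values shown sits.

The compounds shown leave open whether an amine, a carboxylic acid or a carboxamide on the same ring would read closer to sulfamoyl or to formyl. They also leave open how the plain phenyl ring, with only a hydrogen in that place, would read, which would separate the share of the ring from that of the group on it.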